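From Fluoro to Hydroxy on a Weak Growth Inhibitor

The compounds below may be only part of what the source reports. "The series", "measured", "known", "first", "only" and "open" are said of these compounds alone.

In a functional assay on A2780 cells (Homo sapiens) for inhibition, read by sulforhodamine B assay (a lower number here means a stronger inhibitor of growth, a higher number a weaker inhibitor of growth), compound 1 (`Cc1ccc2[nH]c(-c3ccc(-c4ccc(-c5ccc(N(C)C)cc5)cc4)cc3)nc2c1`) reads 2210 nM, while compound 2 (`Fc1ccc(-c2ccc(-c3ccc(-c4nc5ccccc5[nH]4)cc3)cc2)cc1`) reads 48200 nM, the higher number of the two. That gap lies beyond the usual scatter of repeated measurements, so compound 2 stands as the weaker growth inhibitor of this pair.

Compound 3 (`Oc1ccc(-c2ccc(-c3ccc(-c4nc5ccccc5[nH]4)cc3)cc2)cc1`) has not yet been measured. It has hydroxy in place of fluoro on an aromatic carbon, para to a large group (hydroxy in place of fluoro on an aromatic carbon), so that 4-fluorophenyl becomes 4-hydroxyphenyl. For the measured compounds named here, no measured pair shows this change on its own, so any forecast is tentative. With compound 2 at 48200 nM, near the weak end of what has been seen, there is more room for a lower number than for a higher one. A moderate gain in growth inhibition is therefore expected, probably just beyond the scatter, with an estimated step (a 4.0-fold lower number from compound 2 to compound 3 (0.60 log units; beyond the scatter)) toward a lower number. In this assay the estimate for compound 3 is 12000 nM, within an expected range (2500 nM to 50000 nM).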

Compound 3, concentration for 50% growth inhibition: 36000 nM
For compound 3 the middle estimate is 3.0-fold (0.48 log units) below the measured one; low and high end bracket the measured number.
By their numbers in this assay, from the lowest: compound 1; then compounds 3 and 2 (each within the scatter of the next).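

In this assay, hydroxy in place of fluoro on an aromatic carbon, para to a large group, gives a 1.3-fold lower number from compound 2 to compound 3 (0.13 log units; within the scatter). This is the first pair among these compounds that differs in one place, and it shows that 4-fluorophenyl and 4-hydroxyphenyl cannot be told apart in this growth read-out, even though the entering hydroxy brings a hydrogen-bond donor and a hydrogen-bond acceptor that the leaving fluoro does not count. No outside measurement bears on this result, so the reading stands here without an explanation.

On these data alone, whether another group at this place, such as an amine, a carboxylic acid or a methoxy group, would read apart from fluoro and hydroxy remains open, as does whether the same exchange would also leave the number within the scatter on the core of compound 1. Compound 1 differs from the other two compounds in more than one place, so these data cannot assign its separate reading to any single part of its structure.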